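Amide nitrogen aryl swap in the paw edema series

A few compounds are considered here, and "the series" means these few. Any claim that something is new, unique, unknown or untested is made for them only; others in the source may bear on it.

Compound 1 `COc1ccc(-n2nc(C(N)=O)nc2-c2cc(OC)c(OC)c(OC)c2)cc1` carries a free primary amide on the shared core; in a functional assay on the whole organism for inhibition, with Rattus norvegicus as the target, read by paw edema, with stated times of 30 min and 4 h, at a dose of 0.28 mmol/kg by the oral route (a higher number here means more inhibition at the dose given (going by the name of the read-out), a lower number less inhibition), compound 1 gives 71%. Among the measured compounds shown here, compound 2 `COc1ccc(-n2nc(C(=O)Nc3ccccc3OC)nc2-c2cc(OC)c(OC)c(OC)c2)cc1` bears a 2-methoxyphenyl on the amide-type nitrogen, and in this assay compound 2 gives 24%, the lowest of the two numbers so far; the only measured step is a number 47 percentage points lower from compound 1 to compound 2 (beyond the scatter). Compound 3 `COc1ccc(-n2nc(C(=O)Nc3ccc(C(F)(F)F)cc3)nc2-c2cc(OC)c(OC)c(OC)c2)cc1` differs from compound 2 in one place: 4-(trifluoromethyl)phenyl in place of 2-methoxyphenyl on an amide-type nitrogen. For the measured compounds named here, no measured step exchanges one aryl group for another on this nitrogen; the known step only shows that adding an aryl group there lowers the read-out strongly, and says nothing about the identity of that group. The step of a number 6 percentage points higher from compound 2 to compound 3 (within the scatter) is therefore expected to lie within the scatter or only slightly beyond it. For compound 3 the estimate in this assay is 30%, with a range from 10% to 55%.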

Compound 3, a percentage reported as inhibition, in the whole organism at one dose (the size of the read-out at that dose, not a potency): 56%
Beside the measured number, compound 3's estimate is 26 percentage points below it, outside the stated range (above it).
By their numbers in this assay, from the lowest: compound 2; then compound 3; then compound 1.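

The aryl group on the amide-type nitrogen is not interchangeable in this assay: with 4-(trifluoromethyl)phenyl in place of 2-methoxyphenyl, the read-out shows a number 32 percentage points higher from compound 2 to compound 3 (beyond the scatter). Adding an aryl group at this nitrogen therefore need not cost much, since a number 15 percentage points lower from compound 1 to compound 3 (beyond the scatter) is a modest step, whereas a number 47 percentage points lower from compound 1 to compound 2 (beyond the scatter) is a large one, and the primary amide of compound 1 still stays highest of the three. Nothing available bears on why the two aryl groups differ.

The two aryl groups differ in both the substituent and its place on the ring, so 4-methoxyphenyl or 2-(trifluoromethyl)phenyl would be needed to separate those two changes. Unsubstituted phenyl and a simple methyl on this nitrogen also remain open.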